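The compounds below may be only part of what the source reports. "The series", "measured", "known", "first", "only" and "open" are said of these compounds alone.

Working notes on a small series built on one shared core. Compound 1 `CC1=CSC(O)(c2ccc([N+](=O)[O-])cc2)c2noc(=O)n21` was run in a functional assay on A2780/DX3 cells (Homo sapiens) for antiproliferative activity, read by MTT assay, with a stated time of 3 days; on this read-out higher numbers stand for weaker inhibition and lower numbers for stronger inhibition; its result is a limit of the assay rather than a number, and compound 1 gives > 100000 nM. Compound 2 `O=c1onc2n1C=CSC2(O)c1ccc(Cl)cc1` also returns a limit in this assay, at > 100000 nM. Compound 3 `CCCCCCCCCCCCCCCCCCOC1(c2ccc(Br)cc2)SC=C(C)n2c1noc2=O` likewise returns only a limit in this assay, at > 100000 nM. Compound 1 therefore stands on no measured number at all: every result shown coincides at the limit of > 100000 nM in this assay, at which 3 of the 3 values shown sit, and no step between measured compounds can be read from the set.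

Compound 4 `CC1=CSC(O)(c2ccccc2)c2noc(=O)n21` has not yet been measured in this assay. Relative to compound 1 the change is hydrogen in place of nitro on an aromatic carbon. Going by the values given here, none of the measured compounds tells how this position responds, as every value so far is a limit. Because all results shown sit at the limit of > 100000 nM in this assay, at which 3 of the 3 values shown sit, the step in this assay is expected to be none beyond the scatter, which is what the estimated step that the limit leaves unreadable from compound 1 to compound 4 means. Compound 4 is expected to give about 200000 nM in this assay, within a range from 40000 nM to 1000000 nM, and most probably as another limit rather than a number.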

Compound 4, half-maximal inhibitory concentration: > 100000 nM
Compound 4 was reported as a limit; the forecaster's own chance of this, stated with the estimate: 85%; the middle value is on the limit's open side.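

In this assay compound 4 gives > 100000 nM as a limit and not a number. Going by these compounds alone, no step between compound 1 and compound 4 can be read, because both results are limits: the limit of > 100000 nM in this assay, at which 4 of the 4 values shown sit. The compounds shown leave open whether anything on the shared core gives a number in this assay and how hydrogen and nitro on that aromatic carbon would then compare.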